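Swapping the Halogen on the Benzamide: Bromine to Chlorine

The source may report more compounds than this note shows. Statements on the series, on what has been measured and on what is new or still open speak of the compounds shown alone.

Compound 1, `COc1ccc(-c2cnc(NC(=O)C3CCOCC3)n2C)cc1`, gives > 100000 nM in a toxicity assay on THP-1 cells (Homo sapiens) for inhibition (on this read-out lower numbers stand for higher toxicity in this test and higher numbers for lower toxicity in this test), which is a limit of the assay and not a number.
Compound 2, `COc1ccc(-c2cnc(NC(=O)c3ccccc3)n2C)cc1`, gives > 100000 nM in this assay, again a limit and not a number.
Compound 3, `COc1ccc(-c2cnc(NC(=O)c3ccc(Br)cc3)n2C)cc1`, gives > 100000 nM in this assay, once more a limit and not a number.

All three compounds share the same core and differ only in the group on the carbonyl carbon. Compound 3 therefore stands at the ceiling of what the test reports, exactly where the other two values sit: the limit of > 100000 nM in this assay, at which 3 of the 3 values shown sit. The three measured steps that touch this part of the molecule, a step that the two limits leave unreadable from compound 1 to compound 2, a step that the two limits leave unreadable from compound 1 to compound 3 and a step that the two limits leave unreadable from compound 2 to compound 3, all run between two limits, so their size cannot be read at all.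

The next compound, compound 4, `COc1ccc(-c2cnc(NC(=O)c3cccc(Cl)c3)n2C)cc1`, is reached by the change (3-chlorophenyl in place of 4-bromophenyl on a carbonyl carbon). Going by the values given here, since every comparable step so far is hidden behind the limit, no readable step in this assay is expected here either, neither up nor down beyond the scatter; the expected step is a number no higher from compound 3 to compound 4 (the limit leaves the size open). Compound 4 is therefore estimated to give about 100000 nM, with a range from 50000 nM to 200000 nM, and most likely the assay will again report only a limit.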

Compound 4, half-maximal cytotoxic concentration: > 28000 nM
Compound 4 gave a limit, no number; the forecaster's own chance of this, stated with the estimate: 85%; the middle value is on the limit's open side.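

Compound 4 gives > 28000 nM in this assay, which is a limit and not a number. Its steps to compound 1, compound 2 and compound 3 all run between two limits, so none of them can be read. The compounds shown leave open whether any of these groups on the carbonyl carbon changes the read-out, as none has a measured number.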